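Chloro to bromo at compound 3: working notes

This account rests on a few compounds, and the source may have more. Where it says the series, first, only, none or still open, it means among the compounds named here.

In a functional assay on HepG2 cells (Homo sapiens) for cytotoxicity, read by MTT assay, with a stated time of 24 h (on this read-out higher numbers stand for weaker inhibition and lower numbers for stronger inhibition), compound 1 (`O=C(Nc1ccc(C(F)(F)F)cc1)c1cc(Cl)ccc1O`) gives 5800 nM and compound 2 (`CC(=O)c1ccc(NC(=O)c2cc(Cl)ccc2O)cc1`) gives 7900 nM. Compound 2 therefore stands level with compound 1 within the scatter, and only these two numbers exist so far. Compound 3 (`CC(=O)c1ccc(NC(=O)c2cc(Br)ccc2O)cc1`) differs from compound 2 at one place: bromo in place of chloro on an aromatic carbon, para to a hydroxy group. Among the compounds with values here, no measured step touches this halogen. Within the data shown here, the only step available, a 1.4-fold higher number from compound 1 to compound 2 (0.13 log units; within the scatter), with acetyl in place of trifluoromethyl, bears on it only indirectly and stays within the scatter. No step beyond the scatter is therefore expected in this assay. The expected value for compound 3 is 7000 nM, with an estimated range of 3000 nM to 15000 nM. This estimate amounts to an expected 1.1-fold lower number from compound 2 to compound 3 (0.05 log units; within the scatter).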

Compound 3, half-maximal inhibitory concentration: 15900 nM
For compound 3 the middle estimate is 2.3-fold (0.36 log units) below the measured one; the whole stated range lies below it.
By their numbers in this assay, from the lowest: compounds 1, 2 and 3 (each within the scatter of the next, the first and the last beyond it).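

Within the data shown here, this is the first measured step at the halogen para to a hydroxy group: in this assay, bromo in place of chloro gives a 2.0-fold higher number from compound 2 to compound 3 (0.30 log units; within the scatter). Chloro and bromo at this aromatic carbon therefore stand level within the scatter, although this rests on a single pair that carries acetyl on the other aromatic ring and sets no pattern for the series. No measurement available here bears on the reason for this result.

The compounds shown carry only chloro or bromo at this place, so the outcome with an amine, a carboxylic acid or a nitrile on this carbon remains open. Also open, going by these compounds, is whether the same exchange stays within the scatter when trifluoromethyl replaces acetyl, as in compound 1.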